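The source may report more compounds than this note shows. Statements on the series, on what has been measured and on what is new or still open speak of the compounds shown alone.

Measured compounds:
- Compound 1, `C=CCn1c(=O)n(C2C[C@H](O)C(CO)O2)c2nc(N)nc(O)c21`: 100 uM
- Compound 2, `Nc1nc(O)c2c(n1)n(C1OC(CO)[C@@H](O)[C@H]1O)c(=O)n2Cc1ccc(Cl)cc1`: 180 uM
- Compound 3, `C=CCn1c(=O)n(C2C=CC(CO)O2)c2nc(N)nc(O)c21`: 11 uM

All three share one core and were tested in a functional assay on YAC-1 cells (Mus musculus) for activation; on this read-out lower numbers stand for an effect already at smaller amounts and higher numbers for an effect only at larger amounts of compound. Compound 2 gives the highest of the three numbers, 180 uM. Compound 1, with 100 uM, lies within the usual scatter of compound 2, so the two cannot be told apart on this read-out. Within the data shown here, compound 3, with 11 uM, lies clearly beyond that scatter and therefore acts at smaller amounts than compound 2; the sugar parts of compound 2 and compound 3 differ in more than one place, so no single step can be drawn between them.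

The compound not yet measured is compound 4, `NC(=O)Cn1c(=O)n(C2OC(CO)[C@@H](O)[C@H]2O)c2nc(N)nc(O)c21`. It keeps the sugar of compound 2 and differs only at the group on the chain carbon: carbamoyl in place of 4-chlorophenyl on a saturated chain carbon bound to an aromatic nitrogen.

Among the measured compounds shown here, there is no measured step that isolates this kind of change, so the expectation rests on compound 2 alone. The step of a 1.4-fold higher number from compound 2 to compound 4 (0.14 log units; within the scatter) in this assay is expected to be small and, if anything, toward a larger amount, staying near the scatter. Compound 4 is estimated at 250 uM, with a range from 60 uM to 1000 uM, and a real chance that this assay reports only a limit.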

Compound 4, concentration for half-maximal effect: 90 uM
Compound 4: the middle estimate sits 2.8-fold (0.44 log units) above what was measured; the measured number falls inside the stated range.
By their numbers in this assay, from the lowest: compound 3; then compounds 4, 1 and 2 (each within the scatter of the next).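

In this assay, carbamoyl in place of 4-chlorophenyl on a saturated chain carbon bound to an aromatic nitrogen gives a 2.0-fold lower number from compound 2 to compound 4 (0.30 log units; within the scatter), the first single-place step at this position in the compounds shown. The change is large on paper, since a smaller group with no ring and with a hydrogen-bond donor and acceptor replaces a six-membered aromatic ring of carbon only, yet compound 2 and compound 4 cannot be told apart on this read-out, so for this pair the exchange of groups leaves no effect that stands clear of the scatter. Nothing measured here speaks to why these two numbers stay so close.

From the compounds shown here alone, whether a different group at this place, such as an amine, a carboxylic acid or a longer chain, would move the number beyond the scatter remains open, because one step cannot show a trend across groups. Also open, going by these compounds, is whether the same exchange would give a similar step on the sugar of compound 3, which reads 11 uM in this assay and so starts from a smaller amount.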